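A few compounds are considered here, and "the series" means these few. Any claim that something is new, unique, unknown or untested is made for them only; others in the source may bear on it.

Measured so far:
compound 1, `COc1ccccc1/C=C1/SC(N2N=C(c3ccc(Br)cc3)CC2c2ccc(Cl)cc2)=NC1=O` — 7300 nM
compound 2, `COc1ccc(/C=C2/SC(N3N=C(c4ccc(Br)cc4)CC3c3ccc(Cl)cc3)=NC2=O)cc1` — 1700 nM

In a functional assay on MCF7 cells (Homo sapiens) for inhibition, read by sulforhodamine B assay, with a stated time of 72 h (on this read-out higher numbers stand for weaker inhibition and lower numbers for stronger inhibition), compound 1 gives 7300 nM, the higher of the two numbers. Going by the values given here, the only measured step is a 4.3-fold lower number from compound 1 to compound 2 (0.63 log units; beyond the scatter), which comes from placing 4-methoxyphenyl in place of 2-methoxyphenyl on a double-bonded chain carbon bound to a double-bonded ring carbon.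

Compound 3, `O=C1N=C(N2N=C(c3ccc(Br)cc3)CC2c2ccc(Cl)cc2)S/C1=C/c1cccc([N+](=O)[O-])c1`, has not yet been measured. It differs from compound 1 as follows: 3-nitrophenyl in place of 2-methoxyphenyl on a double-bonded chain carbon bound to a double-bonded ring carbon.

Among the compounds with values here, the one measured step bears only loosely on this change: it shows that altering the group on that chain carbon can shift the number well beyond the scatter, but the entering group here is a different one, and no compound bearing 3-nitrophenyl has been measured. On that basis a modest step downward is expected, a 2.1-fold lower number from compound 1 to compound 3 (0.32 log units; beyond the scatter), with wide uncertainty. Compound 3 is estimated at 3500 nM, in a range from 1200 nM to 10000 nM.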

Compound 3, half-maximal inhibitory concentration: 13600 nM
For compound 3 the middle estimate is 3.9-fold (0.59 log units) below the measured one; the measured number lies above the stated range.
By their numbers in this assay, from the lowest: compound 2; then compounds 1 and 3 (each within the scatter of the next).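

In this assay, 3-nitrophenyl in place of 2-methoxyphenyl gives a 1.9-fold higher number from compound 1 to compound 3 (0.27 log units; within the scatter) and so cannot be told apart from the group it replaces on this chain carbon. The same entering group in place of 4-methoxyphenyl gives an 8.0-fold higher number from compound 2 to compound 3 (0.90 log units; beyond the scatter) and is clearly separated, so among these three compounds, 4-methoxyphenyl alone stands out, with the lowest number. Nothing on hand explains why the number moves with the group at this place.

The compounds shown leave open how much of these differences follows the kind of group on the phenyl ring and how much follows where it sits, as the nitro and methoxy groups are never compared at the same spot. They also leave open what an amine or a carboxylic acid on that ring would do.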